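Furan to Pyrrole Swap in Rat Paw Edema Inhibition

The source may hold more compounds than are shown below. What is called first, only, known or untested is meant among the compounds shown, and "the series" means these compounds.

Of the compounds shown here, three have been tested in a functional assay on the whole organism (strain Wistar Albino) for inhibition, with Rattus norvegicus as the target, read by paw edema, with a stated time of 2 h, at a dose of 20 mg/kg; a higher number here means more inhibition at the dose given (going by the name of the read-out), a lower number less inhibition. Compound 1, `COc1ccc(Cl)c(-c2nnc3n2NC(c2ccco2)S3)c1`, gives 18.7%. Compound 3, `COc1ccc(Cl)c(-c2nnc3n2NC(c2ccc[nH]2)S3)c1`, gives 15.2%. Compound 2, `Cc1occc1-c1nnc2n1NC(c1ccco1)S2`, gives 21.6%. The difference between the core of compound 1 and the core of compound 2 is not broken down here. Compound 3 differs from compound 1 in one place only: 1H-pyrrol-2-yl in place of furan-2-yl on a saturated ring carbon. The resulting step, a number 3.5 percentage points lower from compound 1 to compound 3 (within the scatter), is small. All three readings lie within the usual scatter of one another, so none of them can be set above or below the others with confidence.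

Compound 4, `Cc1occc1-c1nnc2n1NC(c1ccc[nH]1)S2`, has not yet been measured in this assay. Relative to compound 2 it carries 1H-pyrrol-2-yl in place of furan-2-yl on a saturated ring carbon. This is the same change as the one already measured, and it occurs twice among the compounds shown, once measured and once not. For compound 4 the expected step is a number 3.6 percentage points lower from compound 2 to compound 4 (within the scatter), beside the measured one. That expectation rests on the measured step of a number 3.5 percentage points lower from compound 1 to compound 3 (within the scatter) and on the reading of compound 2, 21.6%. Compound 4 is therefore estimated at 18% in this assay, with a likely range from 10% to 27%. Whether the second swap behaves like the first remains to be seen once the measurement is in hand.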

Compound 4, a percentage reported as inhibition, in the whole organism at one dose (the size of the read-out at that dose, not a potency): 18.2%
Estimate against measurement, compound 4: 0.2 percentage points below, and the stated range covers the measured number.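

On a second core, in this assay, the exchange of furan-2-yl for 1H-pyrrol-2-yl on the saturated ring carbon gives a number 3.4 percentage points lower from compound 2 to compound 4 (within the scatter). Set beside the earlier result, the change carries over from one core to the other with no detectable difference in size: the same change on two cores in this assay, a number 3.5 percentage points lower (within the scatter) from compound 1 to compound 3 and a number 3.4 percentage points lower (within the scatter) from compound 2 to compound 4, 0.1 percentage points apart, within the scatter of two such steps Agreement between these two steps does not show that the swap truly alters inhibition, since each step lies within the scatter on its own, and two cores tested at a single dose and a single time are too few to support a rule for the whole series.

The compounds shown hold only two groups at the saturated ring carbon, both five-membered aromatic rings with one hetero atom, so it remains open whether something quite different there, such as a carboxylic acid, an amine or a longer chain, would shift the reading beyond the scatter. From the compounds shown here alone, it also remains open whether the close match between the two steps would hold on cores with other substituents in place of the groups carried by compound 1 and compound 2.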